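A Propyl Group Added to Compound 2

The source may report more compounds than this note shows. Statements on the series, on what has been measured and on what is new or still open speak of the compounds shown alone.

Three compounds have so far been measured in an assay for inhibition of beta-glucuronidase (Bos taurus), read by spectrophotometry, with a stated time of 30 min; a higher number here means a weaker inhibitor, a lower number a stronger inhibitor:

Compound 1 `CCCCCCCCS(=O)(=O)Nc1cnc2ccccc2c1` gives 75100 nM.
Compound 2 `O=S(=O)(Oc1cccc2cccnc12)c1ccccc1` gives 49500 nM.
Compound 3 `O=[N+]([O-])c1cccc(S(=O)(=O)Oc2cccc3cccnc23)c1` gives 30100 nM.

Compound 2 has the second highest of the three numbers. Its nearest neighbour is compound 1, whose number is higher but within the usual scatter, so the two cannot be told apart. Toward compound 3 there is a 1.6-fold lower number from compound 2 to compound 3 (0.22 log units; within the scatter), again a change too small to count as real.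

Compound 4 `CCCc1ccc(S(=O)(=O)Oc2cccc3cccnc23)cc1` differs from compound 2 in one place: propyl in place of hydrogen on an aromatic carbon. Among the measured compounds shown here, the only measured change on this ring is the one from compound 2 to compound 3, a nitro in place of hydrogen, and it stayed within the scatter. For the measured compounds named here, no measured step involves a propyl or any other small chain on this ring, so the bearing of this particular change is unknown. The expectation is therefore a step about as small as the one already seen, a 1.2-fold lower number from compound 2 to compound 4 (0.09 log units; within the scatter), with no clear direction. For compound 4 the estimated value in this assay is 40000 nM, expected to fall between 15000 nM and 110000 nM.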

Compound 4, half-maximal inhibitory concentration: 84400 nM
For compound 4 the middle estimate is 2.1-fold (0.32 log units) below the measured one; low and high end bracket the measured number.
By their numbers in this assay, from the lowest: compounds 3, 2, 1 and 4 (each within the scatter of the next, the first and the last beyond it).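

In this assay, propyl on an aromatic carbon of the six-membered ring, para to a large group, gives a 1.7-fold higher number from compound 2 to compound 4 (0.23 log units; within the scatter), so compound 2 and compound 4 cannot be told apart. Among the compounds shown here, the only other measured change on this ring, nitro in place of hydrogen, gives a 1.6-fold lower number from compound 2 to compound 3 (0.22 log units; within the scatter), and a chain of 3 carbon atoms now joins it as a second change that stays within the scatter. Nothing at hand explains why this step is so small.

Going by these compounds, it remains open whether a longer chain such as hexyl, or an amine or a carboxylic acid, at this same place would shift the number beyond the scatter. For the compounds shown here, with only this one propyl step here, it is also unsettled whether this position matters in this assay at all.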